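Anilino variation at the core of compound 3

The source may report more compounds than this note shows. Statements on the series, on what has been measured and on what is new or still open speak of the compounds shown alone.

Measured values in a functional assay on PC-3 cells (Homo sapiens) for cytotoxicity, read by MTT assay, with a stated time of 72 h; a lower number here means a stronger inhibitor, a higher number a weaker inhibitor:
- compound 1 `CCCCCCCCCCCCCCNc1nc(SCc2ccc(C(F)(F)F)cc2)nc2ccccc12`: > 50000 nM
- compound 2 `FC(F)(F)c1ccc(CSc2nc(Nc3ccccc3)c3ccccc3n2)cc1`: 20000 nM
- compound 3 `FC(F)(F)c1ccc(CSc2nc(Nc3ccccc3Cl)c3ccccc3n2)cc1`: 20400 nM

The value of compound 1 in this assay is a limit of the assay, not a number. Compound 2 and compound 3 sit close together; the step of a 1.0-fold higher number from compound 2 to compound 3 (0.01 log units; within the scatter) is within the scatter, so the two cannot be ordered against each other. Compound 3 thus stands with compound 2 at the measured end of the series, with compound 1 known only as a limit (the limit of > 50000 nM in this assay, at which 1 of the 3 values shown sits).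

Compound 4 `FC(F)(F)c1ccc(CSc2nc(Nc3cccc(C(F)(F)F)c3)c3ccccc3n2)cc1` differs from compound 3 in one place: 3-(trifluoromethyl)phenyl in place of 2-chlorophenyl on a nitrogen on an aromatic ring. Among the compounds with values here, the only measured step at this position is the one from compound 2 to compound 3, which was within the scatter. Within the data shown here, no measured step bears directly on a trifluoromethyl substituent on this ring. The expectation for this assay is therefore a step of no size beyond the scatter.

Compound 4 is expected to give 22000 nM, with a range of 8000 nM to 60000 nM. The estimated step of a 1.1-fold higher number from compound 3 to compound 4 (0.03 log units; within the scatter) is expected to fall within the scatter.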

Compound 4, half-maximal inhibitory concentration: 12900 nM
Beside the measured number, compound 4's estimate is 1.7-fold (0.23 log units) above it; the measured number falls inside the stated range.
By their numbers in this assay, from the lowest: compounds 4, 2 and 3 (each within the scatter of the next). At a limit, above all of these: compound 1.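

In this assay, trifluoromethyl in place of hydrogen on the anilino phenyl ring gives a 1.6-fold lower number from compound 2 to compound 4 (0.19 log units; within the scatter), and 3-(trifluoromethyl)phenyl in place of 2-chlorophenyl gives a 1.6-fold lower number from compound 3 to compound 4 (0.20 log units; within the scatter). Until now this position had only the chloro step to go on; a second substituent, on a group of 10 heavy atoms rather than 7, also leaves the number within the scatter. Compound 2, compound 3 and compound 4 therefore form one group that cannot be ordered, and neither substituent shown separates itself from the unsubstituted phenyl.

Compound 1 remains a limit of the assay, not a number: the limit of > 50000 nM in this assay, at which 1 of the 4 values shown sits. Still open, from the compounds shown here alone, is whether an amine or a carboxylic acid on this phenyl ring would give a step beyond the scatter.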